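The source may hold more compounds than are shown below. What is called first, only, known or untested is meant among the compounds shown, and "the series" means these compounds.

Measured in a functional assay on PC-3 cells (Homo sapiens) for inhibition, read by MTT assay, with a stated time of 48 h; on this read-out lower numbers stand for stronger inhibition and higher numbers for weaker inhibition:
- compound 1 `COc1cc(/C=C2\SC(=O)N(CCNC(=O)Nc3c(C)n(C)n(-c4ccccc4)c3=O)C2=O)cc(OC)c1OC`: 35400 nM
- compound 2 `Cc1ccc(/C=C2\SC(=O)N(CC(=O)Nc3c(C)n(C)n(-c4ccccc4)c3=O)C2=O)cc1`: 45300 nM

Compound 1 at 35400 nM and compound 2 at 45300 nM lie within the usual scatter of each other, so the two cannot be ordered. Among the compounds with values here, compound 2 therefore stands level with the only other measured compound.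

Compound 3 `COc1ccc(/C=C2\SC(=O)N(CC(=O)Nc3c(C)n(C)n(-c4ccccc4)c3=O)C2=O)cc1` departs from compound 2 in one place: methoxy in place of methyl on an aromatic carbon. This puts methoxy in place of methyl on an aromatic carbon, turning 4-methylphenyl into 4-methoxyphenyl. Within the data shown here, no measured pair differs in one place, so the data give no direct guide to this change. No step beyond the scatter is expected in this assay, and the reference point remains compound 2 at 45300 nM. The expected size of the change is a 1.1-fold lower number from compound 2 to compound 3 (0.05 log units; within the scatter). For compound 3 the estimate is 40000 nM, with an expected range of 15000 nM to 90000 nM.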

Compound 3, half-maximal inhibitory concentration: 93700 nM
The estimate for compound 3 lay 2.3-fold (0.37 log units) below the measured number; measured number outside the range, above it.
By their numbers in this assay, from the lowest: compounds 1 and 2 (each within the scatter of the next); then compound 3.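

Within the data shown here, this is the first pair that differs in one place. In this assay the exchange of 4-methylphenyl for 4-methoxyphenyl gives a 2.1-fold higher number from compound 2 to compound 3 (0.32 log units; beyond the scatter) and so a modest weakening of inhibition beyond the scatter. The aromatic carbon para to a large group is therefore not indifferent to this exchange, although nothing measured here accounts for the step.

As far as these compounds go, it remains open whether this step is particular to methoxy or extends to other groups on the same carbon, such as hydroxyl, chlorine or an amine. Also open, from the compounds shown here alone, is whether methoxy on another carbon of this ring would give a step of similar size and direction.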